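This account rests on a few compounds, and the source may have more. Where it says the series, first, only, none or still open, it means among the compounds named here.

The series shares one core, carrying a (4-fluorophenyl)amino group and a methylpiperazinyl-substituted anilino group, and varies the substituent on a ring nitrogen of that core. Compound 1 `CN1CCN(c2ccc(Nc3ncc4nc(Nc5ccc(F)cc5)n([C@H]5CCNC5)c4n3)cc2)CC1` and compound 2 `CN1CCN(c2ccc(Nc3ncc4nc(Nc5ccc(F)cc5)n(CCNS(=O)(=O)C5CC5)c4n3)cc2)CC1` belong to it but have no result: in a functional assay on A-431 cells (Homo sapiens) for antiproliferative activity, read by MTT assay, with a stated time of 72 h (a higher number here means a weaker inhibitor, a lower number a stronger inhibitor), compound 1 gives "not determined" (no result reported), and compound 2 gives "not determined" (no result reported). Compound 3 `CN1CCN(c2ccc(Nc3ncc4nc(Nc5ccc(F)cc5)n([C@@H]5CCN(S(=O)(=O)C6CC6)C5)c4n3)cc2)CC1` carries a 1-(cyclopropylsulfonyl)pyrrolidin-3-yl group at that position. In this assay compound 3 gives > 10000 nM, which is a limit of the assay and not a number. Compound 3 therefore sits at the limit of > 10000 nM in this assay, at which 1 of the 3 values shown sits.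

Compound 4 `CN1CCN(c2ccc(Nc3ncc4nc(Nc5ccc(F)cc5)n(-c5cccc(NC(=O)CO)c5)c4n3)cc2)CC1` changes only that substituent: 3-(((hydroxymethyl)carbonyl)amino)phenyl in place of 1-(cyclopropylsulfonyl)pyrrolidin-3-yl on an aromatic nitrogen. Among the measured compounds shown here, no measured step exists between any two compounds here, so the size of this change can only be expected. Given that compound 3 reports > 10000 nM, any reported number for compound 4 would already be a gain. The author expects a step of an at least 3.3-fold lower number from compound 3 to compound 4 (0.52 log units; beyond the scatter) toward stronger inhibition, while a second limit remains quite possible. Compound 4 is estimated at 3000 nM, with a range from 300 nM to 20000 nM.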

Compound 4, half-maximal inhibitory concentration: 1670 nM
Beside the measured number, compound 4's estimate is 1.8-fold (0.25 log units) above it; low and high end bracket the measured number.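

Replacing 1-(cyclopropylsulfonyl)pyrrolidin-3-yl with 3-(((hydroxymethyl)carbonyl)amino)phenyl on this aromatic nitrogen gives an at least 5.9-fold lower number from compound 3 to compound 4 (0.77 log units; beyond the scatter) in this assay, showing that a compound with this core and a substituent at this position can return a measured value. The value of compound 3 is a limit of the assay and not a number, so the step fixes only a smallest size for this change: the limit of > 10000 nM in this assay, at which 1 of the 4 values shown sits. The exchange alters several things at once, swapping two non-aromatic rings for a six-membered aromatic ring and adding hydrogen-bond donors, and the step cannot be divided among these differences.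

Steps involving compound 1 and compound 2 cannot be read. As far as these compounds go, it remains open whether the aromatic ring or its side chain accounts for the gain, and how a plain phenyl, or a phenyl carrying an amine or a carboxylic acid, would compare with compound 4.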